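Working notes on a carbamoyl amine series

The compounds below may be only part of what the source reports. "The series", "measured", "known", "first", "only" and "open" are said of these compounds alone.

For the measured compounds named here, compound 2 `Nc1nn(C(=O)Nc2ccc(Cc3ccccc3)cc2)c2ccccc12` is the only member with a number in a functional assay on HCC 2998 cells (Homo sapiens) for inhibition, read by sulforhodamine B assay, with a stated time of 48 h; on this read-out higher numbers stand for weaker inhibition of growth and lower numbers for stronger inhibition of growth: compound 2 gives 4270 nM. Compound 1 `O=C(Nc1ccc(Cc2ccccc2)cc1)Nc1nn(C(=O)Nc2ccc(Cc3ccccc3)cc2)c2ccccc12` gives only a limit there, > 100000 nM. Compound 3 `COc1ccc(NC(=O)Nc2n[nH]c3ccccc23)cc1` likewise gives only a limit, > 100000 nM. The picture is summed up by the limit of > 100000 nM in this assay, at which 2 of the 3 values shown sit. Compound 4 `CCCCOc1ccc(NC(=O)n2nc(N)c3ccccc32)cc1` differs from compound 2 by butoxy in place of benzyl on an aromatic carbon. Going by the values given here, no measured pair shows a step of this kind, so its size is not known from the data. A modest weakening rather than no change is expected, and the expected step is a 1.9-fold higher number from compound 2 to compound 4 (0.27 log units; within the scatter). For compound 4 the estimate in this assay is 8000 nM, with a range from 2500 nM to 30000 nM.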

Compound 4, concentration for 50% growth inhibition: 19000 nM
Beside the measured number, compound 4's estimate is 2.4-fold (0.38 log units) below it; the measured number falls inside the stated range.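

In this assay, the change from benzyl to butoxy on an aromatic carbon, para to a large group, now has a measured size: a 4.4-fold higher number from compound 2 to compound 4 (0.65 log units; beyond the scatter). The position therefore accepts loss of the benzyl ring at a cost beyond the scatter, yet compound 4 keeps a measured value and does not join the compounds at the limit: the limit of > 100000 nM in this assay, at which 2 of the 4 values shown sit.

Still open, on these data alone, is whether the step follows the loss of the ring or the entry of the oxygen. A butyl chain or a phenoxy group at this place would separate the two.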